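This account rests on a few compounds, and the source may have more. Where it says the series, first, only, none or still open, it means among the compounds named here.

Compound 1, `Cc1ccc2nc([C@H](CC3CCN(CC(C)C)CC3)N3C(=O)CN(c4ccc(Oc5ccccc5)cc4)C3=O)n(C)c2c1`, in an assay on cells for antagonist activity at Bile acid receptor (Homo sapiens), read by a luciferase reporter, with a stated time of 24 h; a higher number here means a weaker inhibitor, a lower number a stronger inhibitor: 17400 nM.
Compound 2, `CC(=O)N1CCC(C[C@@H](c2nc3ccc(C)cc3n2C)N2C(=O)CN(c3ccc(Oc4ccccc4)cc3)C2=O)CC1`, in this assay: 0.2 nM.
Compound 3, `Cc1ccc2nc([C@H](CC3CCN(C(=O)C(C)C)CC3)N3C(=O)CN(c4ccc(Oc5ccccc5)cc4)C3=O)n(C)c2c1`, in this assay: < 0.001 nM, which is a limit of the assay and not a number.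

The three measured compounds share one core and differ only in the group on the amine nitrogen in the ring. Going from compound 1 to compound 2 gives an 87000-fold lower number from compound 1 to compound 2 (4.94 log units; beyond the scatter). Going from compound 1 to compound 3 gives an at least 17000000-fold lower number from compound 1 to compound 3 (7.24 log units; beyond the scatter). The change in the amide substituent, an at least 200-fold lower number from compound 2 to compound 3 (2.30 log units; beyond the scatter), is the step that bears most directly on compound 4. Compound 3 stands at the floor of what the assay reports, as the limit of < 0.001 nM in this assay, at which 1 of the 3 values shown sits, shows.

Compound 4, `Cc1ccc2nc([C@H](CC3CCN(C(=O)C4CCCC4)CC3)N3C(=O)CN(c4ccc(Oc5ccccc5)cc4)C3=O)n(C)c2c1`, differs from compound 3 by cyclopentyl in place of isopropyl on a carbonyl carbon. Among the compounds with values here, the only measured step at this position, from compound 2 to compound 3, was large and downward, and compound 3 already sits at the assay limit, so there is no room for a further measurable fall. Compound 4 is therefore expected to come back as a limit as well, with a number no lower from compound 3 to compound 4 (the limit leaves the size open) as the estimated step. For compound 4 the estimate is 0.001 nM, within 0.0001 nM to 0.02 nM.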

Compound 4, half-maximal inhibitory concentration: 0.006 nM
Compound 4: middle estimate off by 6.0-fold (0.78 log units), on the low side, and the stated range covers the measured number.
By their numbers in this assay, from the lowest: compound 4; then compound 2; then compound 1. At a limit, below all of these: compound 3.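

Within the data shown here, with cyclopentyl in place of isopropyl on a carbonyl carbon, the series turns upward for the first time (an at least 6.0-fold higher number from compound 3 to compound 4 (0.77 log units; beyond the scatter)), so the fall seen on going from methyl to isopropyl at this place does not carry on to this larger group with its five-membered ring. Cyclopentyl still keeps most of the gain over methyl (a 33-fold lower number from compound 2 to compound 4 (1.52 log units; beyond the scatter)), and cyclopentylcarbonyl in place of isobutyl on the amine nitrogen in the ring gives a very large fall (a 2900000-fold lower number from compound 1 to compound 4 (6.46 log units; beyond the scatter)), so all three amides shown now lie far under the isobutyl compound. Compound 3 remains a limit of the assay and not a number, so the rise to compound 4 has a lower bound but no fixed size: the limit of < 0.001 nM in this assay, at which 1 of the 4 values shown sits.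

On these data alone, it remains open whether a phenyl ring or a tert-butyl group on the carbonyl carbon would track isopropyl or cyclopentyl. As far as these compounds go, it is also open whether a sulfonyl group on the amine nitrogen in the ring would keep numbers as low as those of the amides, or whether the carbonyl is needed at all.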